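The source may report more compounds than this note shows. Statements on the series, on what has been measured and on what is new or still open speak of the compounds shown alone.

Measured to date:
Compound 1, `COc1ccc(/C=C\C(=O)O[C@@H](C)[C@@H]2CC[C@H]([C@H](O)[C@H]3CC=CC(=O)O3)O2)cc1`: in a functional assay on MCF7 cells (Homo sapiens) for inhibition, read by sulforhodamine B assay, with a stated time of 72 h (on this read-out higher numbers stand for weaker inhibition and lower numbers for stronger inhibition), compound 1 gives > 10000 nM, which is a limit of the assay and not a number.
Compound 2, `C[C@H](OC(=O)/C=C\c1ccc(O)cc1)[C@@H]1CC[C@H]([C@H](O)[C@H]2CC=CC(=O)O2)O1`: in this assay compound 2 gives 9300 nM.
Compound 3, `COc1ccc(/C=C/C(=O)O[C@@H](C)[C@@H]2CC[C@H]([C@H](O)[C@H]3CC=CC(=O)O3)O2)cc1`: in this assay compound 3 gives > 10000 nM, again a limit of the assay.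

Compound 3 therefore stands at the limit of > 10000 nM in this assay, at which 2 of the 3 values shown sit, and nothing in this assay places it relative to compound 1. The step that the two limits leave unreadable from compound 1 to compound 3 cannot be sized, both of its values being limits; the two compounds share (the fact that compounds 1 and 3 differ only in the configuration as drawn).

Compound 4, `C[C@H](OC(=O)/C=C/c1ccc(O)cc1)[C@@H]1CC[C@H]([C@H](O)[C@H]2CC=CC(=O)O2)O1`, is reached from compound 3 by hydrogen in place of methyl on an oxygen on an aromatic ring. For the measured compounds named here, the only measured step that bears on this change is the same replacement made on the other geometric isomer, an at least 1.0-fold lower number from compound 1 to compound 2 (0.03 log units; that floor lies within the scatter), which starts from a limit and lands on a number that lies within the scatter of that limit. On this one precedent the change is expected to produce no step beyond the scatter in this assay, so a step of about a number no higher from compound 3 to compound 4 (the limit leaves the size open) is expected. Compound 4 is estimated at 10000 nM in this assay, with a range from 5000 nM to 20000 nM, and a real chance that the assay again reports only a limit.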

Compound 4, half-maximal inhibitory concentration: > 10000 nM
Compound 4 was reported as a limit; the forecaster's own chance of this, stated with the estimate: 55%; the middle value lies on the limit itself.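

In this assay compound 4 gives > 10000 nM, which is a limit of the assay and not a number, so the hydroxy compound with the E double bond also gives no measured value: the limit of > 10000 nM in this assay, at which 3 of the 4 values shown sit.

Methoxy to hydroxy on the E double bond therefore has no readable size, and the same holds for every step with a limit at both ends. The one readable step involving compound 4 is an at least 1.0-fold higher number from compound 2 to compound 4 (0.03 log units; that floor lies within the scatter), so the Z and E forms of the 4-hydroxyphenyl compound are not separated in this assay, and this pair adds a second comparison of double-bond geometry: the fact that compounds 2 and 4 differ only in the configuration as drawn

The compounds shown leave open how far compounds 1, 3 and 4 lie past the limit, and whether double-bond geometry has any real effect on the read-out. Also open, as far as these compounds go, is what an amine or a carboxylic acid in place of the methoxy on the aromatic ring, or a longer chain on that oxygen, would do in this assay.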